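Dropping one fluoro from a potent compound

The source may hold more compounds than are shown below. What is called first, only, known or untested is meant among the compounds shown, and "the series" means these compounds.

Measured so far in a functional assay on the whole organism with Mus musculus as the target; a higher number here means that more compound is needed for the effect, a lower number that less compound is needed:
Compound 1 `NCC(=O)NCc1nncn1-c1ccc(Cl)cc1C(=O)c1ccccc1` with 1.37 mg/kg recorded
Compound 2 `Cc1nnc(CNC(=O)CN)n1-c1ccc(Cl)cc1C(=O)c1ccccc1F` with 0.09 mg/kg recorded

Of the two, compound 2 has the lower number (0.09 mg/kg), and the gap to compound 1 lies beyond the usual scatter. Compound 3 `Cc1nnc(CNC(=O)CN)n1-c1ccc(Cl)cc1C(=O)c1ccccc1` has not yet been measured. Its difference from compound 2 is hydrogen in place of fluoro on an aromatic carbon and amounts to hydrogen in place of fluoro on an aromatic carbon, or 2-fluorophenyl to phenyl. Among the compounds with values here, no measured pair isolates this change. Within the data shown here, the only guide is compound 1, which also carries a benzoyl group and gives the higher number (1.37 mg/kg). An upward step of moderate size, probably beyond the scatter, is therefore expected in this assay. The expected change is a 3.9-fold higher number from compound 2 to compound 3 (0.59 log units; beyond the scatter) in this estimate. For compound 3 the estimated value is 0.35 mg/kg with an expected range from 0.12 mg/kg to 1.1 mg/kg in this assay.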

Compound 3, dose for half-maximal effect: 0.38 mg/kg
Compound 3: middle estimate off by 1.1-fold (0.04 log units), on the low side; measured number inside the range.
By their numbers in this assay, from the lowest: compound 2; then compound 3; then compound 1.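

In this assay, taking away the fluoro gives a 4.2-fold higher number from compound 2 to compound 3 (0.63 log units; beyond the scatter) on an otherwise unchanged structure, so the 2-fluorophenyl to phenyl change has a measurable effect of its own at this position. Compound 3 also isolates the other change, with methyl in place of hydrogen on an aromatic carbon giving a 3.6-fold lower number from compound 1 to compound 3 (0.56 log units; beyond the scatter) in the same assay, so the two changes that separate compound 1 from compound 2 can now be read singly, and each lowers the number by a modest step. No measurement at hand bears on why either change has this effect.

As far as these compounds go, it remains open whether chloro or methoxy in place of the fluoro would give a number as low as that of compound 2. Also open, from the compounds shown here alone, is whether the fluoro would give a step of similar size on the core without the methyl, and whether ethyl could replace that methyl.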